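A few compounds are considered here, and "the series" means these few. Any claim that something is new, unique, unknown or untested is made for them only; others in the source may bear on it.

Going by the values given here, compound 1 `COc1ccc(/C=C/c2cc(OC)cc(OC)c2/C=C/C(=O)c2cc3cc(Br)ccc3oc2=O)cc1` is the only compound in this small set with a numerical reading: in an assay on isolated protein for inhibition of Amine oxidase [flavin-containing] A (Homo sapiens), read by fluorescence, with a stated time of 15 min (on this read-out lower numbers stand for stronger inhibition and higher numbers for weaker inhibition), compound 1 gives 12100 nM. Compound 2 `COc1ccc(/C=C/c2cc(OC)cc(OC)c2/C=C/C(=O)c2cc3cc(Br)cc(OC)c3oc2=O)cc1` reaches only a limit of the assay, reported as > 60000 nM. Among the compounds with values here, the single measured step, an at least 4.9-fold higher number from compound 1 to compound 2 (0.69 log units; beyond the scatter), thus corresponds to the limit of > 60000 nM in this assay, at which 1 of the 2 values shown sits, and it shows that adding a methoxy on an aromatic carbon of the shared core weakened inhibition.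

Compound 3 `COc1ccc(/C=C/c2cc(OC)cc(OC)c2/C=C/C(=O)c2cc3cccc(C)c3oc2=O)cc1` has not yet been measured. It differs from compound 1 by a group of 12 heavy atoms (10 carbon, 2 oxygen; one six-membered aromatic ring of carbon only, one six-membered aromatic ring with 1 hetero atom) in place of a group of 12 heavy atoms (9 carbon, 2 oxygen, 1 bromine; one six-membered aromatic ring of carbon only, one six-membered aromatic ring with 1 hetero atom), on a carbonyl carbon. Within the data shown here, no measured pair covers this exact exchange; the step from compound 1 to compound 2 is the only guide, and it suggests that substitution on that part of the core is not easily tolerated. Since the bromine of compound 1 is also lost, a weaker inhibition than that of compound 1 is expected, a step of a 1.8-fold higher number from compound 1 to compound 3 (0.26 log units; within the scatter) in this assay, though the change might also leave the value within the scatter. Compound 3 is therefore estimated at 22000 nM, within a range of 7000 nM to 60000 nM.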

Compound 3, half-maximal inhibitory concentration: > 60000 nM
Compound 3 gave a limit, no number; the forecaster's own chance of this, stated with the estimate: 30%; middle value at least 2.7-fold (0.43 log units) away from the limit.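

Exchanging the bromine-bearing group on the carbonyl carbon for the group of 10 carbon and 2 oxygen atoms gives an at least 4.9-fold higher number from compound 1 to compound 3 (0.69 log units; beyond the scatter), so a second change to compound 1 also weakens inhibition in this assay. Unlike the earlier step, this exchange adds no methoxy, which shows that the loss of inhibition in this small set is not tied to that group, and no compound shown goes against this weakening on change from compound 1. Compound 1 remains the only compound with a numerical reading, and the true sizes of the two steps cannot be set against each other: the limit of > 60000 nM in this assay, at which 2 of the 3 values shown sit.

The compounds shown do not separate the loss of the bromine from the gain of the extra carbon within the exchanged group, so it remains open which of the two carries the step. As far as these compounds go, how a chlorine, an amine or a carboxylic acid in place of the bromine would read in this assay also remains open, as does whether any such group could give stronger inhibition than compound 1.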